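The source may hold more compounds than are shown below. What is called first, only, known or untested is meant among the compounds shown, and "the series" means these compounds.

Compound 3 `Cc1cc(O)cc(-c2nn(CC#N)cc2-c2ccnc(-c3ccc(Oc4ccccc4)cc3)c2)c1` gives 84% in a functional assay on A498 cells (Homo sapiens) for cytotoxicity, read by sulforhodamine B assay, with a stated time of 48 h, tested at 100 nM (a lower number here means a stronger effect, a higher number a weaker effect of the compound at the concentration tested), the highest of the three numbers recorded and thus the weakest effect at this concentration. Compound 1 `COc1cc(C)cc(-c2c(-c3ccnc(-c4ccc(C(C)=O)cc4)c3)cnn2CC#N)c1` gives 65% in this assay, and compound 2 `COc1cc(C)cc(-c2nn(CC#N)cc2-c2ccc(-c3cccc(C(C)=O)c3)nc2)c1` gives 53% in this assay; both gaps to compound 3 lie beyond the scatter. Compound 4 `Cc1cc(O)cc(-c2nn(CC#N)cc2-c2ccnc(-c3ccc(N(C)C)cc3)c2)c1` is not yet measured. It differs from compound 3 by dimethylamino in place of phenoxy on an aromatic carbon. Within the data shown here, no step between measured compounds carries this change, so nothing recorded fixes its size. The expected step in this assay is a number 4 percentage points lower from compound 3 to compound 4 (within the scatter), a change not beyond the scatter in either direction. Compound 4 is therefore estimated at 80% in this assay, with a range from 60% to 100%.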

Compound 4, a percentage reported as activity, at one concentration (the size of the read-out at that concentration, not a potency): 92%
Compound 4: middle estimate off by 12 percentage points, on the low side, and the stated range covers the measured number.
By their numbers in this assay, from the lowest: compound 2; then compound 1; then compounds 3 and 4 (each within the scatter of the next).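

In this assay, among these compounds, dimethylamino in place of phenoxy on an aromatic carbon, para to a large group, gives a number 8 percentage points higher from compound 3 to compound 4 (within the scatter) and is the only single-place step so far. At this position, then, the six-membered aromatic ring of phenoxy can leave, with 3 heavy atoms entering for 7, without a change beyond the scatter.

On these data alone, whether a carboxylic acid or a primary amine in this place would move the number beyond the scatter remains open. Nothing available bears on the reason for this step.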